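The compounds below may be only part of what the source reports. "The series", "measured", "known", "first", "only" and "open" are said of these compounds alone.

Measured so far:
compound 1 `COc1cc(OC)c2c(=O)cc(-c3ccc(OC4CCN(C)CC4)cc3)oc2c1` — 49%
compound 2 `COc1cc(OC)c2c(=O)cc(-c3ccc(OCC(O)CN(C)C)cc3)oc2c1` — 60%
compound 3 `COc1cc(OC)c2c(=O)cc(-c3ccc(Br)cc3)oc2c1` — 10%

In a functional assay (Homo sapiens) for antiproliferative activity, read by resazurin assay, with a stated time of 48 h, tested at 10 uM (on this read-out higher numbers stand for a stronger effect at the one concentration tested and lower numbers for a weaker effect), compound 1 stands second highest of the three numbers, with compound 2 above it and compound 3 well below. The measured steps: a number 11 percentage points higher from compound 1 to compound 2 (beyond the scatter), a modest step; a number 39 percentage points lower from compound 1 to compound 3 (beyond the scatter), a large step; and a number 50 percentage points lower from compound 2 to compound 3 (beyond the scatter), also large. Compound 4 `COc1cc(OC)c2c(=O)cc(-c3ccc(NCCN4CCCC4)cc3)oc2c1` is not yet measured. Its change from compound 1: (2-(pyrrolidin-1-yl)ethyl)amino in place of (1-methylpiperidin-4-yl)oxy on an aromatic carbon. The step from compound 1 to compound 2, an exchange of one nitrogen-containing side chain for another, bears most directly and was modest; the step from compound 1 to compound 3, which replaces the whole side chain with bromo, was large and downward. Compound 4 retains a nitrogen-containing side chain, so no step beyond the scatter is expected, with a number 5 percentage points higher from compound 1 to compound 4 (within the scatter). For compound 4 the estimate is 54%, within 34% to 74%.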

Compound 4, a percentage reported as inhibition, at one concentration (the size of the read-out at that concentration, not a potency): 51%
Estimate against measurement, compound 4: 3 percentage points above, within the range that was stated.
By their numbers in this assay, from the lowest: compound 3; then compounds 1, 4 and 2 (each within the scatter of the next, the first and the last beyond it).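

In this assay this position accepts an amino link in place of an ether oxygen, with a pyrrolidine ring in place of the piperidine, as the readings a number 2 percentage points higher from compound 1 to compound 4 (within the scatter) and a number 9 percentage points lower from compound 2 to compound 4 (within the scatter) stay within the scatter. The large gap to bromo also holds for this amino-linked side chain, with a number 41 percentage points higher from compound 3 to compound 4 (beyond the scatter) as the reading. No measurement on hand explains these readings.

Open, as far as these compounds go, is how a carboxylic acid or a morpholine-ended chain would read at this aromatic carbon. From the compounds shown here alone, a longer chain between the amino link and the pyrrolidine ring also remains open.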